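The source may hold more compounds than are shown below. What is called first, only, known or untested is meant among the compounds shown, and "the series" means these compounds.

Compound 1 `CC1CCN(C2CCN(S(=O)(=O)c3cccc(Br)c3)CC2)CC1` — in a functional assay on DLD-1 cells (Homo sapiens) for antiproliferative activity, read by CellTiter-Glo, with a stated time of 72 h (on this read-out higher numbers stand for weaker inhibition and lower numbers for stronger inhibition), compound 1 gives 3.2 nM.
Compound 2 `Cc1cc(C)c(S(=O)(=O)N2CCC(C3OCC(C)CO3)CC2)c(C)c1` — in this assay compound 2 gives only the assay limit, > 5000 nM.
Compound 3 `Cc1noc(C)c1S(=O)(=O)N1CCC(N2CCC(C)CC2)CC1` — in this assay compound 3 gives only the assay limit, > 5000 nM.

Compound 3 thus sits at the limit of > 5000 nM in this assay, at which 2 of the 3 values shown sit, and is not separated from compound 2 by any number. For the measured compounds named here, the one measured step that bears on it is an at least 1500-fold higher number from compound 1 to compound 3 (3.19 log units; beyond the scatter). Compound 4 `CC1CCN(C2CCN(S(=O)(=O)c3cccnc3Cl)CC2)CC1` reverses that direction: 2-chloropyridin-3-yl in place of 3,5-dimethyl-1,2-oxazol-4-yl on a sulfonyl sulfur. The group entering is again a halogenated six-membered aromatic ring on the sulfonyl sulfur, as in compound 1, so the account expects a large drop in the number for compound 4, an at least 160-fold lower number from compound 3 to compound 4 (2.22 log units; beyond the scatter), though not necessarily all the way to compound 1. The estimate for compound 4 in this assay is 30 nM, between 5 nM and 600 nM.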

Compound 4, half-maximal inhibitory concentration: > 5000 nM
Compound 4: no number, only a limit; the forecaster's own chance of this, stated with the estimate: 15%; middle value at least 160-fold (2.22 log units) away from the limit.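

In this assay compound 4 gives only a limit, > 5000 nM. Putting 2-chloropyridin-3-yl in place of 3-bromophenyl on the sulfonyl sulfur gives an at least 1500-fold higher number from compound 1 to compound 4 (3.19 log units; beyond the scatter), so a halogenated six-membered aromatic ring at this place is not enough to keep the low number. The step between the two limit compounds cannot be read, and the values shown gather at one end: the limit of > 5000 nM in this assay, at which 3 of the 4 values shown sit.

As far as these compounds go, what stays open is whether the ring nitrogen, the halogen or both decide this. A plain phenyl or a 3-chlorophenyl group on the sulfonyl sulfur would bear on that.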